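From trifluoromethyl to chloro in a cytotoxicity series

A few compounds are considered here, and "the series" means these few. Any claim that something is new, unique, unknown or untested is made for them only; others in the source may bear on it.

For the measured compounds named here, in an ADME assay on HepG2 cells (Homo sapiens) for cytotoxicity, read by MTT assay, with a stated time of 24 h (a higher number here means that more compound is tolerated, a lower number that less compound is tolerated), compound 3 `O=C(OCc1cn(-c2ccnc3cc(Cl)ccc23)nn1)c1ccc(C(F)(F)F)cc1` gives 1070000 nM, the only true number among the three compounds measured. Compound 1 `CC(C)(C)c1ccc(C(=O)OCc2cn(-c3ccnc4cc(Cl)ccc34)nn2)cc1` reads > 2380000 nM, which is a limit of the assay. Compound 2 `O=C(OCc1cn(-c2ccnc3cc(Cl)ccc23)nn1)c1ccccc1` reads > 2740000 nM, which is also a limit.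

Compound 4 `O=C(OCc1cn(-c2ccnc3cc(Cl)ccc23)nn1)c1ccc(Cl)cc1` has not yet been measured. It differs from compound 3 by chloro in place of trifluoromethyl on an aromatic carbon, with chloro in place of trifluoromethyl on an aromatic carbon.

Going by the values given here, two measured steps bear on this change: an at least 2.5-fold lower number from compound 2 to compound 3 (0.40 log units; beyond the scatter), and an at least 2.2-fold lower number from compound 1 to compound 3 (0.34 log units; beyond the scatter). Both end at the trifluoromethyl compound, while a step that the two limits leave unreadable from compound 1 to compound 2 gives no size to work from. Among the compounds with values here, no chloro compound has been measured, so the expectation for compound 4 stays close to compound 3 at 1070000 nM, with a small rise in this assay as the likelier direction. The expected step is a 1.4-fold higher number from compound 3 to compound 4 (0.15 log units; within the scatter). For compound 4 the estimated value is 1500000 nM, with an expected range of 700000 nM to 3000000 nM.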

Compound 4, half-maximal cytotoxic concentration: 484000 nM
Beside the measured number, compound 4's estimate is 3.1-fold (0.49 log units) above it; measured number below the stated range.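

Swapping trifluoromethyl for chloro on the six-membered aromatic ring in this assay gives a 2.2-fold lower number from compound 3 to compound 4 (0.34 log units; beyond the scatter), so this position responds even to a change between two halogen-bearing groups, which compound 3 alone could not show. Both an at least 5.6-fold lower number from compound 2 to compound 4 (0.75 log units; beyond the scatter) and an at least 4.9-fold lower number from compound 1 to compound 4 (0.69 log units; beyond the scatter) start from a limit of the assay, not from a number. Compound 4 is therefore the least tolerated of the four compounds, and among these four alone the two halogen-bearing groups read lower than hydrogen and tert-butyl, with chloro lower than trifluoromethyl.

No measurement shown accounts for this order. On these data alone, whether fluoro or bromo would continue it at this position stays open, as does the reading for an amine or a carboxylic acid there.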